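The compounds below may be only part of what the source reports. "The series", "measured", "known", "first", "only" and "open" are said of these compounds alone.

Measured compounds:
Compound 1 `Cc1c(OCCCCOc2cccc(C(=O)O)c2)ccc(C(=O)CC2CCCC2)c1O` in an assay on HEK293 cells for positive allosteric modulation of metabotropic glutamate receptor 2 (Rattus norvegicus), read by thallium flux, with a stated time of 2.5 min (a lower number here means a smaller maximal response, a higher number a larger maximal response), gives 80.6%.
Compound 2 `Cc1c(OCCCCOc2ccc(C(=O)O)cc2)ccc(C(=O)CC(C)C)c1O` in this assay gives 88%.
Compound 3 `Cc1c(OCCCCOc2ccc(C(=O)O)cc2Cl)ccc(C(=O)CC(C)C)c1O` in this assay gives 99.5%.

Compound 3 has the highest of the three numbers; compound 2 sits nearest to it and compound 1 furthest, both beyond the scatter. The not yet measured compound 4 `Cc1c(OCCCCOc2cccc(C(=O)O)c2)ccc(C(=O)CC(C)C)c1O` differs from compound 3 in one place: 3-carboxyphenyl in place of 4-carboxy-2-chlorophenyl on an oxygen on a saturated carbon. This change does two things at once: the chlorine is removed, and the carboxy group sits at a different position on the ring. Among the compounds with values here, only one measured step bears on it directly. Adding the chlorine gave a number 11.5 percentage points higher from compound 2 to compound 3 (beyond the scatter), so taking it away again is expected to cost about as much. Within the data shown here, no single step separates the two carboxy positions: compound 1 and compound 2 differ in the chain as well, so their values can only hint that the position of the carboxy group matters little. Compound 4 is therefore expected to land near compound 2, a step of a number 13.5 percentage points lower from compound 3 to compound 4 (beyond the scatter), with an estimate of 86% and a range from 72% to 100%.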

Compound 4, largest response reached (reported as percent of maximum), in percent of the reference or control that the assay uses: 84.5%
Beside the measured number, compound 4's estimate is 1.5 percentage points above it; the range from low to high includes it.
By their numbers in this assay, from the lowest: compounds 1, 4 and 2 (each within the scatter of the next); then compound 3.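

Placing the carboxy group differently on the ring, with the rest of the molecule unchanged, gives a clean comparison for the first time in this assay: 3-carboxyphenyl in place of 4-carboxyphenyl gives (a number 3.5 percentage points lower from compound 2 to compound 4 (within the scatter)), so these two placements cannot be told apart here. Isopropyl in place of cyclopentyl likewise gives (a number 3.9 percentage points higher from compound 1 to compound 4 (within the scatter)), so the two chain ends cannot be told apart either. The change that also removes the chloro group, by contrast, gives (a number 15 percentage points lower from compound 3 to compound 4 (beyond the scatter)), which fits the chlorine-bearing compound 3 standing apart from the other three.

No measurement here offers an explanation for any of these steps. Going by these compounds, it stays open whether a chloro group on the 3-carboxyphenyl ring would raise the response as well, and whether a fluoro group could do the same.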